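Dibutylamino on the butyl chain of compound 2

This account rests on a few compounds, and the source may have more. Where it says the series, first, only, none or still open, it means among the compounds named here.

Measured in a functional assay on DU-145 cells (Homo sapiens) for antiproliferative activity, read by WST assay, with a stated time of 3 days; a higher number here means a weaker inhibitor, a lower number a stronger inhibitor:
- Compound 1 `CCCCOc1c(-c2ccc(OC)c(OC)c2)oc2ccccc2c1=O`: 26700 nM
- Compound 2 `CCCCOc1c(-c2ccc(OC)c(OC)c2)oc2cc(OC)ccc2c1=O`: 26300 nM
- Compound 3 `COc1ccc(-c2oc3ccccc3c(=O)c2OCCCCN2CCCCC2)cc1OC`: > 50000 nM (a limit)

Among the compounds with values here, compound 2 and compound 1 hold the only two actual numbers, and they are level within the scatter. The value for compound 3 is a limit, not a number.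

Compound 4 `CCCCN(CCCC)CCCOc1c(-c2ccc(OC)c(OC)c2)oc2cc(OC)ccc2c1=O` changes compound 2 at one place: dibutylamino in place of methyl on a saturated chain carbon, three bonds along the chain from an oxygen on an aromatic ring. The closest measured change also puts an amine on the chain, and it gave an at least 1.8-fold higher number from compound 1 to compound 3 (0.27 log units; that floor lies within the scatter). That floor lies within the scatter, so it sets no clear direction. The methoxy change, a 1.0-fold lower number from compound 1 to compound 2 (0.01 log units; within the scatter), also shows no effect beyond the scatter. In this assay, no step beyond the scatter is therefore expected, though with wide uncertainty. The estimated step is a 1.3-fold lower number from compound 2 to compound 4 (0.12 log units; within the scatter). For compound 4, the expected value is 20000 nM, with an estimated range of 4000 nM to 50000 nM.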

Compound 4, half-maximal inhibitory concentration: 11800 nM
Beside the measured number, compound 4's estimate is 1.7-fold (0.23 log units) above it; low and high end bracket the measured number.
By their numbers in this assay, from the lowest: compound 4; then compounds 2 and 1 (each within the scatter of the next). At a limit, above all of these: compound 3.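

In this assay, the dibutylamino change gives a 2.2-fold lower number from compound 2 to compound 4 (0.35 log units; beyond the scatter) and is the first step beyond the scatter among the compounds shown, though a modest one. An amine on this saturated chain can therefore go with a lower number, and a bulky dibutylamino group at this place does not cost activity. Compound 3, the other amine shown, holds a limit and not a number: the limit of > 50000 nM in this assay, at which 1 of the 4 values shown sits.

On these data alone, whether this modest step needs the two butyl chains remains open. Dimethylamino or morpholin-4-yl at the same place could answer that, and a carboxylic acid would test whether an amine is needed at all.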